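The compounds below may be only part of what the source reports. "The series", "measured", "known", "first", "only" and "open" are said of these compounds alone.

Values so far in a functional assay on MCF7 cells (Homo sapiens) for cytotoxicity, read by MTT assay, with a stated time of 72 h; a higher number here means a weaker inhibitor, a lower number a stronger inhibitor:
- Compound 1 `CNC(=O)c1cc(Oc2ccc(NC(=O)c3cc(-c4ccc(Cl)cc4)ncn3)cc2F)ccn1`: > 100000 nM (a limit)
- Compound 2 `CCc1ccc(-c2cc(C(=O)Nc3ccc(Oc4ccnc(C(=O)NC)c4)c(F)c3)ncn2)cc1`: 7630 nM

Going by the values given here, compound 2 holds the only actual number in this assay. For compound 1 the reading is a limit, (the limit of > 100000 nM in this assay, at which 1 of the 2 values shown sits).

Compound 3 `CNC(=O)c1cc(Oc2ccc(NC(=O)c3cc(-c4ccc(C)cc4)ncn3)cc2F)ccn1` differs from compound 2 by hydrogen in place of methyl on a saturated chain carbon bound to an aromatic carbon, so that 4-ethylphenyl becomes 4-methylphenyl. Among the compounds with values here, one measured step bears on this change: an at least 13-fold lower number from compound 1 to compound 2 (1.11 log units; beyond the scatter), a large step from ethyl in place of chloro on an aromatic carbon. That step does not compare methyl with ethyl, so it gives only a loose guide. A moderate move towards a higher number is expected, smaller than that large step.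

The expected change is a 2.6-fold higher number from compound 2 to compound 3 (0.42 log units; beyond the scatter). For compound 3 the estimated value is 20000 nM, with an expected range of 7000 nM to 70000 nM.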

Compound 3, half-maximal inhibitory concentration: 19200 nM
Estimate against measurement, compound 3: 1.0-fold (0.02 log units) above; the range from low to high includes it.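

In this assay, the change from 4-ethylphenyl to 4-methylphenyl gives a 2.5-fold higher number from compound 2 to compound 3 (0.40 log units; beyond the scatter), so the size of the alkyl group on this ring matters, and the earlier chloro-to-ethyl step could not show that. Methyl in place of chloro gives an at least 5.2-fold lower number from compound 1 to compound 3 (0.71 log units; beyond the scatter), which places methyl between chloro and ethyl in this assay, with compound 2 holding the lowest number of the three. The reading for compound 1 is a limit, so steps from it give only a minimum size: the limit of > 100000 nM in this assay, at which 1 of the 3 values shown sits.

As far as these compounds go, whether a longer chain such as propyl, or a branched isopropyl, would lower the number further remains open. How a methoxy group or an amine would read on this ring also remains open, as the compounds shown carry only chloro, methyl and ethyl there.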